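Dibromo-hydroxybenzamide series: removing the ring chloro

This account rests on a few compounds, and the source may have more. Where it says the series, first, only, none or still open, it means among the compounds named here.

Measured so far in an assay for inhibition of HSP60/HSP10 (Homo sapiens), with a stated time of 60 min; a lower number here means a stronger inhibitor, a higher number a weaker inhibitor:
- compound 1, `COc1ccc(Br)cc1C(=O)Nc1ccc(Sc2nc3ccccc3s2)cc1`: > 100000 nM
- compound 2, `COc1ccccc1C(=O)Nc1ccc(Sc2nc3ccccc3s2)cc1`: > 100000 nM
- compound 3, `O=C(Nc1ccc(Sc2nc3ccccc3s2)c(Cl)c1)c1cc(Br)cc(Br)c1O`: 4200 nM

Compound 1 `COc1ccc(Br)cc1C(=O)Nc1ccc(Sc2nc3ccccc3s2)cc1` gives only a limit in this assay, > 100000 nM. Compound 2 `COc1ccccc1C(=O)Nc1ccc(Sc2nc3ccccc3s2)cc1` likewise gives only a limit, > 100000 nM. Among the compounds with values here, the one step between measured compounds, a step that the two limits leave unreadable from compound 1 to compound 2, therefore cannot be read for size or direction, since both ends sit at the limit (the limit of > 100000 nM in this assay, at which 2 of the 3 values shown sit).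

Within the data shown here, compound 3 `O=C(Nc1ccc(Sc2nc3ccccc3s2)c(Cl)c1)c1cc(Br)cc(Br)c1O` is the only compound with a number in this assay, 4200 nM. Compound 1 and compound 2 give only limits, so the standing of compound 3 relative to them is not known in size.

Compound 4 `O=C(Nc1ccc(Sc2nc3ccccc3s2)cc1)c1cc(Br)cc(Br)c1O` has not been measured. It differs from compound 3 by hydrogen in place of chloro on an aromatic carbon. Among the measured compounds shown here, no measured step bears on this change: the single step available is unreadable, and neither compound 1 nor compound 2 carries the chloro or the dibromo-hydroxy pattern. Expectation rests on compound 3 alone, with 4200 nM as the anchor. With no evidence either way, the step of a 1.4-fold higher number from compound 3 to compound 4 (0.15 log units; within the scatter) is estimated to stay within, or just beyond, the usual scatter. Compound 4 is accordingly expected to give 6000 nM, with a range of 2000 nM to 20000 nM.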

Compound 4, half-maximal inhibitory concentration: 4700 nM
Estimate against measurement, compound 4: 1.3-fold (0.11 log units) above, within the range that was stated.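

In this assay, the chloro on the aromatic carbon, ortho to a large group and meta to a large group, gives way to hydrogen with no readable difference: a 1.1-fold higher number from compound 3 to compound 4 (0.05 log units; within the scatter). With the chloro gone, a single change now connects the dibromo-hydroxy pattern to the methoxy pattern, and 3,5-dibromo-2-hydroxyphenyl in place of 2-methoxyphenyl on the carbonyl carbon gives an at least 21-fold lower number from compound 2 to compound 4 (1.32 log units; beyond the scatter), while the same group in place of 5-bromo-2-methoxyphenyl gives an at least 21-fold lower number from compound 1 to compound 4 (1.32 log units; beyond the scatter). Both of these steps start from a limit of the assay, so each printed size is a minimum and the full size stays unknown: the limit of > 100000 nM in this assay, at which 2 of the 4 values shown sit.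

It remains open which part of the exchange carries these steps, since no compound shown has the hydroxy without the two bromo groups, or the two bromo groups with a methoxy. Also open, going by these compounds, is whether compound 4, at 4700 nM, would hold its number with an amine or a carboxylic acid in place of the hydrogen on that aromatic carbon.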